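A Shift From Fluorophenyl to Acetylphenyl at the Same Carbon

The source may hold more compounds than are shown below. What is called first, only, known or untested is meant among the compounds shown, and "the series" means these compounds.

All compounds here share one core, seen in compound 1 `CN(CC1=CC[C@H]2C[C@@H]1C2(C)C)Cc1ccc(Cl)cc1`, which in an assay on HEK293 cells for displacement of a labelled ligand from C-X-C chemokine receptor type 3 (Homo sapiens) (on this read-out higher numbers stand for weaker inhibition and lower numbers for stronger inhibition), gives 2510 nM. Compound 2 `CN(CC1=CC[C@H]2C[C@@H]1C2(C)C)Cc1ccc(Br)cc1` carries bromo in place of chloro and in this assay gives 3160 nM, and the step of a 1.3-fold higher number from compound 1 to compound 2 (0.10 log units; within the scatter) lies within the scatter. Compound 3 `CN(CC1=CC[C@H]2C[C@@H]1C2(C)C)Cc1ccc(-c2ccccc2F)cc1` carries 2-fluorophenyl at that carbon. For compound 3 this assay reports only a limit, > 316 nM, so its exact standing is not known (the limit of > 316 nM in this assay, at which 1 of the 3 values shown sits). The steps a step that the limit leaves unreadable from compound 1 to compound 3 and a step that the limit leaves unreadable from compound 2 to compound 3 therefore cannot be sized.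

Compound 4 `CC(=O)c1cccc(-c2ccc(CN(C)CC3=CC[C@H]4C[C@@H]3C4(C)C)cc2)c1` differs from compound 3 by 3-acetylphenyl in place of 2-fluorophenyl on an aromatic carbon. Within the data shown here, no measured step bears directly on this change: the only readable step, a 1.3-fold higher number from compound 1 to compound 2 (0.10 log units; within the scatter), concerns a small halogen swap and says nothing about exchanging one aryl group for another. No step beyond the scatter is therefore expected in this assay, and the expected step that the limit leaves unreadable from compound 3 to compound 4 rests on weak ground. Because compound 1 gives 2510 nM and compound 2 gives 3160 nM, compound 4 is expected near 2000 nM, between 300 nM and 15000 nM.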

Compound 4, inhibition constant: > 316 nM
Compound 4: only a limit was reported; the forecaster's own chance of this, stated with the estimate: 50%; the middle value is on the limit's open side.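

In this assay compound 4 gives > 316 nM as a limit and not a number. Its steps to compound 1, compound 2 and compound 3 therefore cannot be read, and the same limit recurs: the limit of > 316 nM in this assay, at which 2 of the 4 values shown sit. The compounds shown leave open how compound 3 and compound 4 truly stand against each other and against compound 1 and compound 2.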